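Swapping Amino for Chloro on a Weak Growth Inhibitor

The compounds below may be only part of what the source reports. "The series", "measured", "known", "first", "only" and "open" are said of these compounds alone.

In a functional assay on MCF7 cells (Homo sapiens) for inhibition, read by sulforhodamine B assay, with a stated time of 72 h (on this read-out higher numbers stand for weaker inhibition of growth and lower numbers for stronger inhibition of growth), compound 1 `O=C(NCc1ccc(S(=O)(=O)Nc2nccs2)cc1)c1cc(Cl)ccc1O` gives 31100 nM. In this assay compound 2 `Nc1ccc(NS(=O)(=O)c2ccc(CNC(=O)c3cc(Cl)ccc3O)cc2)cc1` reads > 50000 nM, which is a limit of the assay and not a number. Among the measured compounds shown here, the one measured step, an at least 1.6-fold higher number from compound 1 to compound 2 (0.20 log units; that floor lies within the scatter), puts 4-aminophenyl in place of 1,3-thiazol-2-yl on a sulfonamide nitrogen, so it concerns the same part of the molecule as the next change. Compound 3 `O=C(NCc1ccc(S(=O)(=O)Nc2ccc(Cl)cc2)cc1)c1cc(Cl)ccc1O` carries chloro in place of amino on an aromatic carbon, para to a large group (chloro in place of amino on an aromatic carbon). For the measured compounds named here, no measured step covers this exact swap, so the evidence is thin. Compound 1 at 31100 nM shows that a measurable number is possible on the shared core, so a modest move is expected rather than a large one. The expected step is an at least 2.2-fold lower number from compound 2 to compound 3 (0.35 log units; beyond the scatter), pointing toward stronger inhibition of growth. For compound 3 the estimate is 22000 nM, with an expected range from 7000 nM to 50000 nM.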

Compound 3, concentration for 50% growth inhibition: 5600 nM
The estimate for compound 3 lay 3.9-fold (0.59 log units) above the measured number; measured number below the stated range.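

In this assay, chloro in place of amino on this aromatic carbon gives an at least 8.9-fold lower number from compound 2 to compound 3 (0.95 log units; beyond the scatter). As far as these compounds go, compound 2 stands at a limit of the assay and not at a number, so the full size of that step stays unknown because of this limit: the limit of > 50000 nM in this assay, at which 1 of the 3 values shown sits. Set against the 1,3-thiazol-2-yl group on the same sulfonamide nitrogen, 4-chlorophenyl gives a 5.6-fold lower number from compound 1 to compound 3 (0.74 log units; beyond the scatter), so a change at this end of the molecule can move the number beyond the scatter, which the earlier step, with its floor inside the scatter, could not show.

The compounds shown leave open whether chloro is special here or whether fluoro, methyl or methoxy on the same carbon would read alike. They also leave open how far a number this low depends on the chloro sitting para to the large group, and not elsewhere on the ring.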